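Swapping 2-fluoroethoxy for 2-hydroxyethoxy at the assay limit

The source may hold more compounds than are shown below. What is called first, only, known or untested is meant among the compounds shown, and "the series" means these compounds.

Measured in an ADME assay (on this read-out higher numbers stand for a longer-lived compound and lower numbers for a shorter-lived compound), each value a limit:
- Compound 1 `COc1ccc(C[S+]([O-])c2ncccc2C(=O)Nc2ccncc2)c(OC)c1`: < 0.02 h
- Compound 2 `COc1cc(OC)c(OC)cc1C[S+]([O-])c1ncccc1C(=O)Nc1ccncc1`: < 0.02 h
- Compound 3 `COc1ccc(C[S+]([O-])c2ncccc2C(=O)Nc2ccncc2)c(OCCF)c1`: < 0.02 h

Compound 3 stands at the limit of < 0.02 h in this assay, at which 3 of the 3 values shown sit. The change to compound 4 `COc1ccc(C[S+]([O-])c2ncccc2C(=O)Nc2ccncc2)c(OCCO)c1` puts hydroxy in place of fluoro on a saturated chain carbon, two bonds along the chain from an oxygen on an aromatic ring. Going by the values given here, two measured steps bear on it: a step that the two limits leave unreadable from compound 1 to compound 3, which created this chain, and a step that the two limits leave unreadable from compound 1 to compound 2. Neither gives a size, so no step beyond the scatter and no direction is expected in this assay. The expected step is a step that the limit leaves unreadable from compound 3 to compound 4. A report at the same limit is the likeliest outcome for compound 4. For compound 4 the estimated half-life is 0.015 h, with an expected range of 0.005 h to 0.04 h.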

Compound 4, half-life: < 0.02 h
Compound 4 was reported as a limit; the forecaster's own chance of this, stated with the estimate: 85%; the middle value lies beyond the limit too.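

In this assay compound 4 gives < 0.02 h, which is a limit. Its steps from compound 1 and from compound 3 therefore cannot be read: the limit of < 0.02 h in this assay, at which 4 of the 4 values shown sit.

The compounds shown leave open whether any of these changes alters half-life, and by how much.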